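The source may report more compounds than this note shows. Statements on the series, on what has been measured and on what is new or still open speak of the compounds shown alone.

Measured so far in an ADME assay on HepG2 cells (Homo sapiens) for cytotoxicity, read by MTT assay, with a stated time of 7 days (a higher number here means a weaker inhibitor, a lower number a stronger inhibitor), as follows:
compound 1 `CCCc1ccc(C2CC(c3ccc(O)cc3)=NN2C(=O)c2cccnc2)cc1` gives 41600 nM
compound 2 `COc1ccc(OC)c(C2CC(c3ccc(O)cc3)=NN2C(=O)c2cccnc2)c1` gives 56800 nM
compound 3 `CCc1ccccc1C1CC(c2ccc(O)cc2)=NN1C(=O)c1cccnc1` gives 35400 nM

Compound 2 56800 nM sits inside the scatter of both other compounds, so the three values read as a single group. The steps that touch it are a 1.4-fold higher number from compound 1 to compound 2 (0.14 log units; within the scatter) and a 1.6-fold lower number from compound 2 to compound 3 (0.21 log units; within the scatter) and neither sets it apart.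

Still unmeasured is compound 4 `Cc1cc(C)c(C2CC(c3ccc(O)cc3)=NN2C(=O)c2cccnc2)c(C)c1` with the change 2,4,6-trimethylphenyl in place of 2,5-dimethoxyphenyl on a saturated ring carbon at the saturated ring carbon of the five-membered non-aromatic ring with 2 nitrogen, next to the ring nitrogen. The 4-hydroxyphenyl and (pyridin-3-yl)carbonyl groups stay as they are.

All three measured steps exchange the group at this same carbon. The closest guide is a 1.6-fold lower number from compound 2 to compound 3 (0.21 log units; within the scatter) as it also removes 2,5-dimethoxyphenyl in favour of an alkyl-substituted phenyl, and a 1.2-fold lower number from compound 1 to compound 3 (0.07 log units; within the scatter) adds a second small step among such groups. Among the compounds with values here, no compound with 2,4,6-trimethylphenyl has been measured, so the guide is indirect.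

No step beyond the scatter is therefore expected in this assay for this change, and the estimated step is a 1.4-fold lower number from compound 2 to compound 4 (0.13 log units; within the scatter) as a working figure. For compound 4 the expected value is 42000 nM with an estimated range from 22000 nM to 80000 nM for repeat measurements.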

Compound 4, half-maximal inhibitory concentration: 54500 nM
Beside the measured number, compound 4's estimate is 1.3-fold (0.11 log units) below it; the range from low to high includes it.
By their numbers in this assay, from the lowest: compounds 3, 1, 4 and 2 (each within the scatter of the next).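

In this assay the exchange of 2,5-dimethoxyphenyl for 2,4,6-trimethylphenyl on the saturated ring carbon gives a 1.0-fold lower number from compound 2 to compound 4 (0.02 log units; within the scatter) as its step, and the new compound stays just as close to the two alkyl-substituted compounds, with a 1.5-fold higher number from compound 3 to compound 4 (0.19 log units; within the scatter) and a 1.3-fold higher number from compound 1 to compound 4 (0.12 log units; within the scatter) both printed inside the scatter. The group at this carbon can therefore carry three methyl groups, as well as one alkyl chain or two methoxy groups, and none of these four substituted phenyl groups stands apart from the others in this assay, so the flat picture from the first three compounds now also covers a group of carbon only with a different substitution pattern. No independent data accompany these numbers to account for this flat picture.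

Going by these compounds, all four compounds carry a substituted phenyl at this carbon, so it remains open whether a basic amine, a carboxylic acid or a much longer chain there would produce a step beyond the scatter. Also open, on these data alone, is how far the numbers depend on the 4-hydroxyphenyl and (pyridin-3-yl)carbonyl groups, which are the same throughout the series.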